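A stereoisomer of compound 2 awaits measurement

A few compounds are considered here, and "the series" means these few. Any claim that something is new, unique, unknown or untested is made for them only; others in the source may bear on it.

Compound 1 `C=C1CC[C@H]2[C@](C)(CO)CCC[C@]2(C)[C@H]1C[C@@]12O[C@@H]1[C@@H](O)C(CO)=CC2=O` at 34200 nM
Compound 2 `C=C1CC[C@H]2[C@](C)(COC(C)=O)CCC[C@]2(C)[C@H]1C[C@]12O[C@H]1[C@H](O)C(CO)=CC2=O` at 37800 nM

Within the data shown here, in a functional assay on HepG2 cells (Homo sapiens) for inhibition, read by MTT assay, with a stated time of 72 h (on this read-out higher numbers stand for weaker inhibition and lower numbers for stronger inhibition), compound 2 stands at 37800 nM and lies within the scatter of compound 1 at 34200 nM on the only two numbers available. Compound 3 `C=C1CC[C@H]2[C@](C)(COC(C)=O)CCC[C@]2(C)[C@H]1C[C@@]12O[C@@H]1[C@@H](O)C(CO)=CC2=O` has the same atoms and bonds as compound 2 and differs only in configuration as drawn (the two compounds have the same atoms and bonds and differ only in configuration as drawn: 3 of 7 stereo elements differ; a stereocentre at a saturated ring carbon is drawn S in compound 2 and R in compound 3; a stereocentre at a saturated ring carbon is drawn S in compound 2 and R in compound 3; a stereocentre at a saturated ring carbon is drawn R in compound 2 and S in compound 3). Among the measured compounds shown here, no measured pair shows what such a change does, so no shift beyond the scatter is expected in this assay for this compound. The expected step is small, a 1.1-fold lower number from compound 2 to compound 3 (0.02 log units; within the scatter) and within the scatter. For compound 3 the estimate is 36000 nM (expected range 15000 nM to 85000 nM).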

Compound 3, half-maximal inhibitory concentration: 27800 nM
For compound 3 the middle estimate is 1.3-fold (0.11 log units) above the measured one; the measured number falls inside the stated range.
By their numbers in this assay, from the lowest: compounds 3, 1 and 2 (each within the scatter of the next).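

In this assay, the inversion of three stereocentres gives a 1.4-fold lower number from compound 2 to compound 3 (0.13 log units; within the scatter), so this change of configuration moves the number by no more than the scatter. At matching configuration, acetyl in place of hydrogen on an oxygen on a saturated carbon gives a 1.2-fold lower number from compound 1 to compound 3 (0.09 log units; within the scatter), which also stays within the scatter. The first comparison isolates stereochemistry alone: the fact that compounds 2 and 3 differ only in the configuration as drawn.

From the compounds shown here alone, whether any single stereocentre matters on its own remains open, since all three change together. Also open, going by these compounds, is whether an amine, a carboxylic acid or a longer chain in place of the acetyl would shift the number beyond the scatter.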